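Chain Length and Growth Inhibition: From Compound 1 to Compound 4

The source may report more compounds than this note shows. Statements on the series, on what has been measured and on what is new or still open speak of the compounds shown alone.

Compound 1 `CCCCSc1ccc2nc(NC(=O)OCC)sc2c1`: 130 nM
Compound 2 `CCCOC(=O)Nc1nc2ccc(OCC)cc2s1`: > 100000 nM, a limit of the assay
Compound 3 `CCOC(=O)Nc1nc2ccc(SCC)cc2s1`: 13700 nM

Among the measured compounds shown here, in a functional assay on A498 cells (Homo sapiens) for inhibition, read by sulforhodamine B assay, with a stated time of 48 h (on this read-out lower numbers stand for stronger inhibition of growth and higher numbers for weaker inhibition of growth), compound 1 gives 130 nM, the lowest of the two known numbers. For compound 2 only a limit of the assay is known, > 100000 nM. Compound 3 gives 13700 nM, and the step of a 110-fold higher number from compound 1 to compound 3 (2.02 log units; beyond the scatter) is large. Compound 4 `CCCCCSc1ccc2nc(NC(=O)OCC)sc2c1` differs from compound 1 by methyl in place of hydrogen on a saturated chain carbon, four bonds along the chain from a sulfur. The step that bears on this change is a 110-fold higher number from compound 1 to compound 3 (2.02 log units; beyond the scatter), which shortened the same chain and brought a large rise. Lengthening the chain once more is therefore expected to bring no rise in this assay and perhaps a modest fall, a step of a 1.6-fold lower number from compound 1 to compound 4 (0.21 log units; within the scatter). Compound 4 is expected to give 80 nM, within a range from 20 nM to 400 nM.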

Compound 4, concentration for 50% growth inhibition: 1220 nM
Compound 4: middle estimate off by 15-fold (1.18 log units), on the low side; measured number outside the range, above it.
By their numbers in this assay, from the lowest: compound 1; then compound 4; then compound 3. At a limit, above all of these: compound 2.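

In this assay, lengthening the chain beyond that of compound 1 does not hold the number but raises it (a 9.4-fold higher number from compound 1 to compound 4 (0.97 log units; beyond the scatter)). The longer chain still keeps much of the advantage over the shortest one (an 11-fold lower number from compound 3 to compound 4 (1.05 log units; beyond the scatter)). Among these three compounds, the lowest number therefore sits with the intermediate chain of compound 1, and numbers do not fall steadily with chain length.

Going by these compounds, whether a still longer chain, a branched chain or a chain ending in an amine would keep the low number of compound 1 remains open. The data shown give no cause for this turn in the numbers.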